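A few compounds are considered here, and "the series" means these few. Any claim that something is new, unique, unknown or untested is made for them only; others in the source may bear on it.

Measured so far:
Compound 1 `Nc1ccc(SCC(=O)Nc2ccc3nc(NC(=O)c4ccc(C(F)(F)F)cc4)sc3c2)cc1`: 100 nM
Compound 2 `CCCC(=O)Nc1nc2ccc(NC(=O)CSc3ccc(Cl)cc3)cc2s1`: 2120 nM

Both compounds were tested in a functional assay on HCT-116 cells (Homo sapiens) for antiproliferative activity, read by MTT assay, with a stated time of 72 h; a lower number here means a stronger inhibitor, a higher number a weaker inhibitor. Compound 1 gives 100 nM, the lower of the two numbers; compound 2 gives 2120 nM, and the gap between them lies well beyond the usual scatter of repeated measurements. Compound 2 differs from compound 1 in more than one place, so nothing can be said about which part of the structure carries that gap.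

The next compound, compound 3 `O=C(CSc1ncccc1C(=O)O)Nc1ccc2nc(NC(=O)c3ccc(C(F)(F)F)cc3)sc2c1`, has not yet been measured. It is a single change from compound 1:

3-carboxypyridin-2-yl in place of 4-aminophenyl on a sulfur

Among the compounds with values here, nothing measured so far shows what a change on this sulfur does, so the expectation rests only on compound 1 and on the kind of change. A new ring with an extra acceptor and a carboxylic acid is a sizeable alteration at this end of the molecule, and the expected outcome is a somewhat weaker inhibitor than compound 1, by a step of a 4.0-fold higher number from compound 1 to compound 3 (0.60 log units; beyond the scatter) in this assay, though a change within the scatter cannot be excluded. Compound 3 is therefore estimated at 400 nM, with a likely range from 80 nM to 2500 nM.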

Compound 3, half-maximal inhibitory concentration: 2300 nM
Compound 3: the middle estimate sits 5.8-fold (0.76 log units) below what was measured; the measured number falls inside the stated range.
By their numbers in this assay, from the lowest: compound 1; then compounds 2 and 3 (each within the scatter of the next).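

In this assay, within the data shown here, the swap of 4-aminophenyl for 3-carboxypyridin-2-yl on the sulfur gives a 23-fold higher number from compound 1 to compound 3 (1.36 log units; beyond the scatter), the first comparison here that isolates this end of the molecule, and it shows that the group on this sulfur can strongly affect the reading even with the rest of compound 1 left unchanged. This single swap still bundles several structural differences, since the amine is gone, a ring nitrogen has entered and a carboxylic acid has been added, so one step cannot assign the loss to any one of them. No measured evidence on the compounds is available to explain the step.

Going by these compounds, it remains open which of these differences carries the step, and whether the amine of compound 1 contributes to its lower number or the carboxylic acid of compound 3 is what raises the number. A plain phenyl, a pyridin-2-yl without the carboxylic acid, or a methyl ester in place of the acid, each on the same sulfur, would help to separate these possibilities.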